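Dropping One Chloro Group From a Dichlorophenyl Amide

The source may report more compounds than this note shows. Statements on the series, on what has been measured and on what is new or still open speak of the compounds shown alone.

Four related compounds are considered here, all built on the same core, and the read-out of interest is an ADME assay on HepG2 cells (Homo sapiens) for cytotoxicity, with a stated time of 3 days; on this read-out lower numbers stand for higher toxicity in this test and higher numbers for lower toxicity in this test. Compound 1 `CC(Sc1nnc(-c2ccncc2)s1)C(=O)NCc1ccc(Cl)cc1` is entered in this assay as "not determined" (no result reported), so it has no reported result. Compound 2 `CC(Sc1nnc(-c2ccncc2)s1)C(=O)NCc1ccccc1` reaches in this assay only a limit of the measurement, > 50000 nM, and no number. Among the measured compounds shown here, compound 3 `O=C(CCSc1nnc(-c2ccncc2)s1)Nc1c(Cl)cccc1Cl` gives 12600 nM in this assay, and this is the only single number among the three entries. Of the other two entries, one is a limit of the measurement and one carries no result at all. That limit is described as the limit of > 50000 nM in this assay, at which 1 of the 3 values shown sits.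

Compound 4 `O=C(CCSc1nnc(-c2ccncc2)s1)Nc1ccccc1Cl` is not yet measured. It differs from compound 3 by hydrogen in place of chloro on an aromatic carbon. For the measured compounds named here, no pair of measured compounds differs in just one place, so there is no measured step to lean on. The expectation is therefore a modest shift at most, if anything toward lower toxicity in this assay, and it may well stay within the usual scatter. The value expected for compound 4 is 20000 nM, within a range from 6000 nM to 60000 nM, which means an estimated step of a 1.6-fold higher number from compound 3 to compound 4 (0.20 log units; within the scatter).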

Compound 4, half-maximal cytotoxic concentration: > 50000 nM
Compound 4: only a limit was reported; the forecaster's own chance of this, stated with the estimate: 35%; at least 2.5-fold (0.39 log units) between middle value and limit.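

The step from 2,6-dichlorophenyl to 2-chlorophenyl is the first single change that can be read among these compounds, and in this assay it gives an at least 3.9-fold higher number from compound 3 to compound 4 (0.59 log units; beyond the scatter). With the rest of the molecule unchanged, replacing this one chloro group with hydrogen moves the read-out beyond the usual scatter, toward lower toxicity in this test, so this position on the aromatic ring matters for the result. The full size of the step remains unknown because compound 4 reached a limit of the measurement rather than giving a number: the limit of > 50000 nM in this assay, at which 2 of the 4 values shown sit.

From the compounds shown here alone, whether the remaining chloro group also contributes, and whether a methyl or methoxy group at the emptied position would behave more like hydrogen or more like chloro, stays open. The compounds shown also do not reveal why losing this chloro group changes the read-out, and a single step cannot show whether the same swap would have a similar effect on a different amide.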